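A few compounds are considered here, and "the series" means these few. Any claim that something is new, unique, unknown or untested is made for them only; others in the source may bear on it.

Measured so far in a functional assay on DU-145 cells (Homo sapiens) for cytotoxicity, read by sulforhodamine B assay, with a stated time of 48 h, tested at 1 uM; a higher number here means a weaker effect of the compound at the concentration tested, a lower number a stronger effect:
compound 1 `COc1ccc(-c2cc(/C=C/C(=O)c3ccc(N)cc3)[nH]n2)cc1` gives 64%
compound 2 `COc1cc(-c2cc(/C=C/C(=O)c3ccc(N)cc3)[nH]n2)cc(OC)c1OC` gives 78%

Going by the values given here, compound 2 stands highest of the two numbers in this assay; its only neighbour is compound 1, whose value lies lower by a margin beyond the usual scatter. Among the compounds with values here, no pair of measured compounds differing in one place is available, so no measured step can be quoted.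

Compound 3 `COc1ccc(-c2cc(/C=C/C(=O)c3ccc(N)cc3)[nH]n2)cc1OC` is not yet measured. Relative to compound 2 the change is hydrogen in place of methoxy on an aromatic carbon. Within the data shown here, in its methoxy pattern compound 3 sits between compound 1 and compound 2, which is the only guide here. The step from compound 2 to compound 3 is expected to be downward and modest, estimated as a number 8 percentage points lower from compound 2 to compound 3 (within the scatter), close to the edge of the scatter. For compound 3 in this assay the estimate is 70%, with a range from 55% to 85%.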

Compound 3, a percentage reported as activity, at one concentration (the size of the read-out at that concentration, not a potency): 97%
Beside the measured number, compound 3's estimate is 27 percentage points below it; measured number above the stated range.
By their numbers in this assay, from the lowest: compound 1; then compound 2; then compound 3.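

In this assay hydrogen in place of methoxy on an aromatic carbon, ortho to a methoxy group, gives a number 19 percentage points higher from compound 2 to compound 3 (beyond the scatter) and so weakens the effect at the concentration tested. Methoxy in place of hydrogen on an aromatic carbon gives a number 33 percentage points higher from compound 1 to compound 3 (beyond the scatter) and also weakens the effect, so both single changes leading to compound 3 run the same way and the read-out does not follow the number of methoxy groups across these compounds. Nothing on hand accounts for this result.

From the compounds shown here alone, it remains open whether a hydroxyl group, a fluorine atom or an ethoxy group at this position would behave like methoxy or like hydrogen. The amine stays the same throughout the compounds shown, so its contribution to the read-out cannot be told from them.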